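Ether to ester on a tetrahydronaphthalene-furan scaffold

This account rests on a few compounds, and the source may have more. Where it says the series, first, only, none or still open, it means among the compounds named here.

Measured compounds:
compound 1 `CCOCc1c(C)coc1-c1ccc2c(c1OC)CCCC2(C)C` 17.7 uM
compound 2 `Cc1coc(-c2ccc3c(c2O)CCCC3)c1C(=O)O` 40.4 uM
compound 3 `Cc1coc(-c2ccc3c(c2O)CCCC3(C)C)c1C(=O)O` 3 uM

Of the compounds shown here, three have been tested in a functional assay on DU-145 cells (Homo sapiens) for cytotoxicity, read by sulforhodamine B assay, with a stated time of 3 days; a lower number here means that less compound is needed, a higher number that more compound is needed for the effect. Compound 1 gives 17.7 uM, the second highest of the three numbers. Its closest neighbour is compound 2, which gives 40.4 uM, a higher number that lies beyond the scatter; compound 3, with its carboxylic acid and gem-dimethyl group, gives 3 uM, the lowest of the three and far below compound 1.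

Compound 4 `COc1c(-c2occ(C)c2COC(C)=O)ccc2c1CCCC2(C)C` keeps the whole core of compound 1 and changes only the substituent on the hydroxymethyl oxygen: acetyl in place of ethyl on an oxygen on a saturated carbon

Going by the values given here, the data show no pair of measured compounds differing in only one place, so no measured step directly informs this change. The exchange of an ether for an ester at the same oxygen is a modest alteration of the side chain, and in this assay the account expects a step from compound 1 to compound 4 of a 1.3-fold lower number from compound 1 to compound 4 (0.10 log units; within the scatter), a change not beyond the scatter, with a slight leaning toward a lower number. For compound 4 the estimated value is 14 uM, with a range of 5 uM to 40 uM.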

Compound 4, concentration for half-maximal effect: 16.7 uM
The estimate for compound 4 lay 1.2-fold (0.08 log units) below the measured number; measured number inside the range.
By their numbers in this assay, from the lowest: compound 3; then compounds 4 and 1 (each within the scatter of the next); then compound 2.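

In this assay, the exchange at this position gives a first direct reading, a 1.1-fold lower number from compound 1 to compound 4 (0.03 log units; within the scatter), and this step lies within the scatter. Ethoxymethyl to acetoxymethyl adds a carbonyl and, by the count of the two groups, one hydrogen-bond acceptor, yet on the core of compound 1 the two compounds cannot be told apart here. The earlier compounds could not show this, as no two of them differed in only one place, and nothing measured here offers an explanation for the result.

The compounds shown leave open whether a longer chain such as butyl, a benzoyl group or a chain carrying an amine on this same oxygen would also stay within the scatter of compound 1. They also do not tell whether acetyl and ethyl would read alike on a core other than that of compound 1, or in any measurement other than this assay.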